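This account rests on a few compounds, and the source may have more. Where it says the series, first, only, none or still open, it means among the compounds named here.

Measured compounds:
- compound 1, `CC(C)(C)OC(=O)CN1C(=O)C(NC(=O)c2ccc(Cl)cc2)CCc2ccccc21`: 130 nM
- compound 2, `CC(C)(C)OC(=O)CN1C(=O)C(NC(=O)c2cc3ccccc3[nH]2)CCc2ccccc21`: 7 nM
- compound 3, `CCOC(=O)CN1C(=O)C(NC(=O)c2cc3ccccc3[nH]2)CCc2ccccc21`: 110 nM

All three were tested in an assay for binding affinity to Cholecystokinin receptor (Rattus norvegicus), read by CCK-8 assay; on this read-out higher numbers stand for weaker inhibition and lower numbers for stronger inhibition. Compound 3 gives 110 nM and stands second highest of the three numbers; its value and that of compound 1 lie within the usual scatter of each other, while compound 2 sits well apart, as a 16-fold higher number from compound 2 to compound 3 (1.20 log units; beyond the scatter) shows. That step, the only measured one touching the same side chain, was large. The other measured step, a 19-fold lower number from compound 1 to compound 2 (1.27 log units; beyond the scatter), concerns a different part of the molecule and gives no guidance here.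

Compound 4, `O=C(NC1CCc2ccccc2N(Cc2ccccc2)C1=O)c1cc2ccccc2[nH]1`, differs from compound 3 in one place: phenyl in place of ethoxycarbonyl on a saturated chain carbon bound to an amide-type nitrogen in a ring. Among the compounds with values here, no measured pair shows this kind of swap, so its direction is open; the step from compound 2 to compound 3 only shows that changes in this region can move the number a great deal. The expected step is therefore a 1.8-fold lower number from compound 3 to compound 4 (0.26 log units; within the scatter), with wide uncertainty. Compound 4 is estimated at 60 nM, within a range from 8 nM to 500 nM.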

Compound 4, half-maximal inhibitory concentration: 35 nM
Estimate against measurement, compound 4: 1.7-fold (0.23 log units) above; low and high end bracket the measured number.
By their numbers in this assay, from the lowest: compound 2; then compound 4; then compounds 3 and 1 (each within the scatter of the next).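

Replacing the ester chain of compound 3 with a benzyl group gives a 3.1-fold lower number from compound 3 to compound 4 (0.50 log units; beyond the scatter) in this assay, so at this position an ester is not required for a low number, even though phenyl brings 0 hydrogen-bond acceptors where ethoxycarbonyl brings 2. The ester group still matters, though: the tert-butyl ester of compound 2 does better than the benzyl group, with a 5.0-fold higher number from compound 2 to compound 4 (0.70 log units; beyond the scatter) in the same assay, which places phenyl between the two esters rather than level with either. No evidence at hand explains this order.

On these data alone, it remains open whether an aromatic ring is what counts here, which a cyclohexylmethyl group on the same nitrogen would test, and how a carboxylic acid or an amine at the end of this chain would read. As far as these compounds go, it is also open whether benzyl would give the same order alongside the 4-chlorophenyl amide of compound 1.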